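From Ethyl to Propargyl: Estimating Compound 3

The source may report more compounds than this note shows. Statements on the series, on what has been measured and on what is new or still open speak of the compounds shown alone.

For the measured compounds named here, only two compounds have numbers so far in a functional assay on NCI-H292 cells (Homo sapiens) for inhibition, read by MTT assay, with a stated time of 72 h; on this read-out lower numbers stand for stronger inhibition and higher numbers for weaker inhibition. Compound 1 `O=C1C=C[C@@H](OC2CCCCC2)O[C@@H]1CO` gives 2600 nM, while compound 2 `CCO[C@@H]1C=CC(=O)[C@@H](CO)O1` gives 18000 nM. That is the higher of the two numbers, so compound 2 is the weaker inhibitor, and the gap lies beyond the usual scatter. Compound 3 `C#CCO[C@@H]1C=CC(=O)[C@@H](CO)O1` alters compound 2 in one place: ethynyl in place of methyl on a saturated chain carbon bound to an oxygen on a saturated carbon. This puts ethynyl in place of methyl on a saturated chain carbon bound to an oxygen on a saturated carbon, turning ethoxy into propargyloxy. Going by the values given here, no measured pair shows this change alone, so the forecast is tentative. Among the compounds with values here, the only hint is compound 1 at 2600 nM, which suggests that a larger group than ethyl may lower the number. A small shift toward stronger inhibition, near the edge of the scatter, is expected, with an estimated step of a 2.0-fold lower number from compound 2 to compound 3 (0.30 log units; within the scatter). For compound 3 the estimated value is 9000 nM, with an expected range of 3000 nM to 25000 nM.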

Compound 3, half-maximal inhibitory concentration: 6600 nM
The estimate for compound 3 lay 1.4-fold (0.13 log units) above the measured number; low and high end bracket the measured number.
By their numbers in this assay, from the lowest: compound 1; then compound 3; then compound 2.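

In this assay, putting ethynyl in place of methyl on a saturated chain carbon bound to an oxygen on a saturated carbon gives a 2.7-fold lower number from compound 2 to compound 3 (0.44 log units; beyond the scatter). For the compounds shown here, this is the first comparison here in which only one group changes, and it shows that turning ethoxy into propargyloxy can shift the number beyond the usual scatter. The step is modest, and the change brings in a triple bond outside aromatic rings without adding any hydrogen-bond donor or acceptor. Nothing measured here explains why the number falls.

The compounds shown leave open whether the triple bond itself matters, as they include no propyl group at this position for comparison. They also leave open how a longer chain or a chain ending in an amine would read out in this assay.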